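The source may hold more compounds than are shown below. What is called first, only, known or untested is meant among the compounds shown, and "the series" means these compounds.

Measured in a functional assay on MCF7 cells (Homo sapiens) for antiproliferative activity, read by MTT assay, with a stated time of 48 h; on this read-out higher numbers stand for weaker inhibition and lower numbers for stronger inhibition:
Compound 1 `CC(=O)N1N=C(c2ccc3ccccc3c2)OC1c1ccc(Cl)cc1` gives 2.63 ug/mL
Compound 2 `CC(=O)N1N=C(c2ccc3ccccc3c2)OC1c1cccc(F)c1` gives 1.98 ug/mL
Compound 3 `CC(=O)N1N=C(c2ccc3ccccc3c2)OC1c1ccccn1` gives 6.02 ug/mL

Compound 3 carries the highest number of the three. Two steps lead up to it: a 2.3-fold higher number from compound 1 to compound 3 (0.36 log units; beyond the scatter) and a 3.0-fold higher number from compound 2 to compound 3 (0.48 log units; beyond the scatter). Compound 4 `CC(=O)N1N=C(c2ccc3ccccc3c2)OC1c1cccnc1` differs from compound 3 as follows: pyridin-3-yl in place of pyridin-2-yl on a saturated ring carbon. That is, pyridin-3-yl stands in place of pyridin-2-yl on a saturated ring carbon. Going by the values given here, no measured step exchanges one pyridinyl group for another, so those two modest steps bear on it only indirectly. A change of similar or smaller size is therefore expected in this assay, with no clear direction. The expected outcome is a 1.2-fold lower number from compound 3 to compound 4 (0.08 log units; within the scatter). For compound 4 the estimated value is 5 ug/mL, with an expected range from 2 ug/mL to 12 ug/mL.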

Compound 4, half-maximal inhibitory concentration: 2.61 ug/mL
Beside the measured number, compound 4's estimate is 1.9-fold (0.28 log units) above it; the range from low to high includes it.
By their numbers in this assay, from the lowest: compounds 2, 4 and 1 (each within the scatter of the next); then compound 3.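

In this assay, going by these compounds alone, the position of the ring nitrogen matters at this saturated ring carbon: the first step between two pyridinyl groups, pyridin-3-yl in place of pyridin-2-yl, gives a 2.3-fold lower number from compound 3 to compound 4 (0.36 log units; beyond the scatter). Pyridin-3-yl also reads alongside the substituted phenyl groups, with a 1.3-fold higher number from compound 2 to compound 4 (0.12 log units; within the scatter) and a 1.0-fold lower number from compound 1 to compound 4 (0.00 log units; within the scatter), so among these four compounds only the pyridin-2-yl of compound 3 stands apart. Nothing available explains this difference between the two pyridinyl groups. The compounds shown leave open how pyridin-4-yl, or a phenyl group carrying a primary amine, would read at this carbon.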